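Epimer of a limit-bound diterpenoid acid

This account rests on a few compounds, and the source may have more. Where it says the series, first, only, none or still open, it means among the compounds named here.

Compound 1 `C=CC(=C)CC[C@@H]1[C@@]2(C)CCC[C@](C)(COC(=O)/C=C/c3ccc(O)cc3)[C@@H]2CC[C@@]1(C)O` gives 16600 nM in a functional assay on MCF7 cells (Homo sapiens) for cytotoxicity, read by MTT assay, with a stated time of 48 h; on this read-out lower numbers stand for stronger inhibition and higher numbers for weaker inhibition. Compound 2 `C=C[C@@]1(C)O[C@H]1C[C@H]1C(=C)CC[C@@H]2[C@]1(C)CCC[C@]2(C)C(=O)O` reaches only the limit of this assay, reported as > 40000 nM, which is a limit and not a number (the limit of > 40000 nM in this assay, at which 1 of the 2 values shown sits). Compound 3 `C=C[C@]1(C)O[C@H]1C[C@H]1C(=C)CC[C@@H]2[C@]1(C)CCC[C@]2(C)C(=O)O` is not yet measured. It differs from compound 2 in one place: the two compounds have the same atoms and bonds and differ only in configuration as drawn: 1 of 6 stereo elements differ; a stereocentre at a saturated ring carbon is drawn R in compound 2 and S in compound 3. Within the data shown here, no measured step between two compounds exists, so the size of such a change cannot be read from the data; the expectation in this assay is for no step beyond the scatter, with compound 3 expected to remain at the limit. Compound 3 is estimated at 45000 nM, within 15000 nM to 150000 nM, an expected step that the limit leaves unreadable from compound 2 to compound 3.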

Compound 3, half-maximal inhibitory concentration: > 40000 nM
Compound 3: only a limit was reported; the forecaster's own chance of this, stated with the estimate: 75%; the middle value lies beyond the limit too.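

No step can be read between compound 2 and compound 3: each stands at a limit of this assay, not at a number. The compounds shown leave open whether the configuration at this saturated ring carbon affects cytotoxicity at all.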